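Amide nitrogen methylation and benzyl methyl placement in the series

The compounds below may be only part of what the source reports. "The series", "measured", "known", "first", "only" and "open" are said of these compounds alone.

Compound 2 `Cc1ccc(CNC(=O)c2nn(-c3ccc(F)cc3)c(OC[C@@H](O)C[C@@H](O)CC(=O)O)c2C(C)C)cc1` carries a hydrogen on the amide-type nitrogen. In a functional assay on L6 cells (Rattus norvegicus) for inhibition (a higher number here means a weaker inhibitor, a lower number a stronger inhibitor), compound 2 gives 2110 nM, the highest of the two numbers available, with compound 1 `Cc1ccc(CN(C)C(=O)c2nn(-c3ccc(F)cc3)c(OC[C@@H](O)C[C@@H](O)CC(=O)O)c2C(C)C)cc1` nearest at 1250 nM. Compound 3 `CC(C)c1c(C(=O)NCc2ccc(Cl)cc2)nn(-c2ccc(F)cc2)c1OC[C@@H](O)C[C@@H](O)CC(=O)O` belongs to the same series, and in this assay compound 3 gives "not determined" (no result reported). Among the compounds with values here, the one step between measured compounds is a 1.7-fold higher number from compound 1 to compound 2 (0.23 log units; within the scatter), which does not separate the two beyond the scatter.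

Compound 4 `Cc1cccc(CN(C)C(=O)c2nn(-c3ccc(F)cc3)c(OC[C@@H](O)C[C@@H](O)CC(=O)O)c2C(C)C)c1` differs from compound 2 by methyl(3-methylbenzyl)amino in place of (4-methylbenzyl)amino on a carbonyl carbon. Within the data shown here, this combines two changes: methyl in place of hydrogen on the amide-type nitrogen, which is the reverse of the step from compound 1 to compound 2, and a shift of the methyl on the benzyl ring from the 4-position to the 3-position, for which no pair gives a comparison. Among the measured compounds shown here, the only bearing step, a 1.7-fold higher number from compound 1 to compound 2 (0.23 log units; within the scatter), lies within the scatter, so the nitrogen methylation is expected to move the number little; the ring methyl shift is unknown and widens the range. Compound 4 is therefore expected to give 1300 nM in this assay, between 450 nM and 3800 nM, a step of a 1.6-fold lower number from compound 2 to compound 4 (0.21 log units; within the scatter) that is not expected to exceed the scatter.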

Compound 4, half-maximal inhibitory concentration: 18500 nM
Estimate against measurement, compound 4: 14-fold (1.15 log units) below; measured number outside the range, above it.
By their numbers in this assay, from the lowest: compounds 1 and 2 (each within the scatter of the next); then compound 4.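

In this assay the ring methyl emerges as the sensitive feature. With the nitrogen methyl held in place, 3-methylphenyl in place of 4-methylphenyl gives a 15-fold higher number from compound 1 to compound 4 (1.17 log units; beyond the scatter) and lies beyond the scatter, whereas the amide nitrogen change alone, a 1.7-fold higher number from compound 1 to compound 2 (0.23 log units; within the scatter) and so within the scatter, did not separate its two compounds. The combined change of (4-methylbenzyl)amino to methyl(3-methylbenzyl)amino on the carbonyl carbon, an 8.8-fold higher number from compound 2 to compound 4 (0.94 log units; beyond the scatter) and also beyond the scatter, agrees with this reading, and nothing at hand accounts for the sensitivity to the ring methyl position.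

Still open, going by these compounds, is whether the 3-position disfavours any group there or only methyl, which a 3-chlorobenzyl or 3-methoxybenzyl amide would test, and whether an unsubstituted benzyl amide stays with compound 1 and compound 2 or moves toward compound 4. Within the data shown here, also open is whether the amide nitrogen stays as indifferent in the 3-methylbenzyl pair as in the 4-methylbenzyl pair, since the only comparison at that nitrogen so far carries the methyl at the 4-position.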